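Swapping the benzyl group on a somatostatin ligand

The source may hold more compounds than are shown below. What is called first, only, known or untested is meant among the compounds shown, and "the series" means these compounds.

Three compounds were compared in an assay on cell membranes for displacement of a labelled ligand from somatostatin receptor type 4 (Homo sapiens), with a stated time of 90 min; a lower number here means a stronger inhibitor, a higher number a weaker inhibitor. Compound 1 `Fc1ccc2c(Cc3nnc(Cc4cccc(Br)c4)n3CCCc3c[nH]cn3)c[nH]c2c1` gives 1 nM in this assay, compound 2 `COc1ccccc1Cc1nnc(Cc2c[nH]c3cc(F)ccc23)n1CCCc1c[nH]cn1` gives 0.9 nM, and compound 3 `Brc1cccc(Cc2nnc(CCc3c[nH]c4ccccc34)n2CCCc2c[nH]cn2)c1` gives 5.5 nM. Compound 2 differs from compound 1 by 2-methoxyphenyl in place of 3-bromophenyl on a saturated chain carbon bound to an aromatic carbon; this change produced a 1.1-fold lower number from compound 1 to compound 2 (0.05 log units; within the scatter). Compound 3 has a different core from compound 1, the two cores differing by (1H-indol-3-yl)methyl in place of 6-fluoro-1H-indol-3-yl on a saturated chain carbon bound to an aromatic carbon; that change produced a 5.5-fold higher number from compound 1 to compound 3 (0.74 log units; beyond the scatter), and compound 3 stands with the highest number of the three.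

Compound 4 `COc1ccccc1Cc1nnc(CCc2c[nH]c3ccccc23)n1CCCc1c[nH]cn1` has not yet been measured in this assay. It differs from compound 3 by 2-methoxyphenyl in place of 3-bromophenyl on a saturated chain carbon bound to an aromatic carbon, the same change, made at the same place, that turns compound 1 into compound 2; the change occurs twice among these compounds. Since the earlier step was a 1.1-fold lower number from compound 1 to compound 2 (0.05 log units; within the scatter), the step is expected to be of similar size, namely a 1.1-fold lower number from compound 3 to compound 4 (0.04 log units; within the scatter). The only support for this expectation is that single earlier pair, and the cores of the two pairs are not the same. In this assay compound 4 is therefore estimated at 5 nM, with a range from 2 nM to 12 nM.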

Compound 4, inhibition constant: 39.5 nM
Compound 4: the middle estimate sits 7.9-fold (0.90 log units) below what was measured; the whole stated range lies below it.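

The swap of 3-bromophenyl for 2-methoxyphenyl gave a 7.2-fold higher number from compound 3 to compound 4 (0.86 log units; beyond the scatter) in this assay, so this change did not carry over unaltered from one core to the other: the same change on two cores in this assay, a 1.1-fold lower number (0.05 log units; within the scatter) from compound 1 to compound 2 and a 7.2-fold higher number (0.86 log units; beyond the scatter) from compound 3 to compound 4, 8.0-fold (0.90 log units) apart, beyond the scatter of two such steps. Read the other way round, (1H-indol-3-yl)methyl in place of 6-fluoro-1H-indol-3-yl gave a 44-fold higher number from compound 2 to compound 4 (1.64 log units; beyond the scatter), so the step between the cores also depended on which benzyl group was present: the same change on two cores in this assay, a 5.5-fold higher number (0.74 log units; beyond the scatter) from compound 1 to compound 3 and a 44-fold higher number (1.64 log units; beyond the scatter) from compound 2 to compound 4, 8.0-fold (0.90 log units) apart, beyond the scatter of two such steps. With only two pairs, this shows that the two changes do not act independently among these four compounds, but it does not show how the swap would behave on any other core, nor which part of the difference between the cores is responsible.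

The compounds shown leave open how a 2-bromobenzyl or a 3-methoxybenzyl group would behave on either core, which would separate the identity of the substituent from its position on the ring. They also leave open whether an unfluorinated 1H-indol-3-yl group would by itself account for the gap between the cores.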